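Removing substituents from the amide in a pyrazole series

This account rests on a few compounds, and the source may have more. Where it says the series, first, only, none or still open, it means among the compounds named here.

Measured so far:
- compound 1 `COc1cc(-c2nn(-c3cccc(NC(=O)c4cccc(C(F)(F)F)c4)c3)cc2-c2ccncc2)ccc1Cl`, > 50000 nM
- compound 2 `COc1cc(-c2nn(-c3cccc(NC(=O)Nc4ccc(Cl)c(Cl)c4)c3)cc2-c2ccncc2)ccc1Cl`, > 50000 nM
- compound 3 `COc1cc(-c2nn(-c3cccc(NC(=O)Nc4ccc(Cl)c(C(F)(F)F)c4)c3)cc2-c2ccncc2)ccc1Cl`, 31000 nM

In a functional assay on HOP-62 cells (Homo sapiens) for inhibition, read by sulforhodamine B assay, with a stated time of 48 h (a higher number here means that more compound is tolerated, a lower number that less compound is tolerated), compound 1 reaches only the limit, > 50000 nM, not a number. Compound 2 likewise gives only the limit, > 50000 nM, in this assay. For the measured compounds named here, compound 3 is the one compound with a real number, 31000 nM. The other two results are limits (the limit of > 50000 nM in this assay, at which 2 of the 3 values shown sit). The steps toward it read an at least 1.6-fold lower number from compound 1 to compound 3 (0.20 log units; that floor lies within the scatter) and an at least 1.6-fold lower number from compound 2 to compound 3 (0.20 log units; that floor lies within the scatter), both only floors that lie within the scatter, while a step that the two limits leave unreadable from compound 1 to compound 2 cannot be read because both ends sit at the limit.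

Compound 4 `COc1cc(-c2nn(-c3cccc(NC(=O)c4ccccc4)c3)cc2-c2ccncc2)ccc1Cl` has not yet been measured in this assay. It differs from compound 3 in one place: phenyl in place of (4-chloro-3-(trifluoromethyl)phenyl)amino on a carbonyl carbon. That change turns the urea back into an amide, as in compound 1, and strips away both the chloro and the trifluoromethyl groups. Going by the values given here, the only related step, an at least 1.6-fold lower number from compound 1 to compound 3 (0.20 log units; that floor lies within the scatter), is small and points from an amide at the limit to a urea with a number. Reversing the direction and losing the halogen groups as well, the expectation is that compound 4 also lands at or beyond the limit, with an estimated 70000 nM (range 25000 nM to 200000 nM). That expected step, a 2.3-fold higher number from compound 3 to compound 4 (0.35 log units; beyond the scatter), is an estimate resting on compound 1 alone.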

Compound 4, concentration lethal to 50% of the cells: > 100000 nM
Compound 4 ended at the assay's limit (the forecaster's own chance of this, stated with the estimate: 70%); middle value at least 1.4-fold (0.15 log units) from the limit.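

In this assay, for the compounds shown here, replacing (4-chloro-3-(trifluoromethyl)phenyl)amino with phenyl on the carbonyl carbon gives an at least 3.2-fold higher number from compound 3 to compound 4 (0.50 log units; beyond the scatter), the first step in this set that clearly exceeds the scatter. Going by these compounds alone, this size is only a floor, and it shows that the one compound with a real number loses that number when the urea becomes an unsubstituted benzamide-type amide, with more compound tolerated. The steps to compound 4 from compound 1 and from compound 2 cannot be read, as each has a limit at both ends, and the highest limit in the set belongs to compound 4 alone: the limit of > 100000 nM in this assay, at which 1 of the 4 values shown sits.

This single change removes the amino nitrogen, the chloro group and the trifluoromethyl group together, so the compounds shown cannot say which of these losses matters, and a urea carrying plain phenylamino on the carbonyl carbon would begin to separate them. Going by these compounds, it also remains open whether other groups on that phenyl ring, such as a methoxy group, an amine or a carboxylic acid, would bring the number down further or leave it at a limit.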